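Adding a bromine to a weakly cytotoxic chalcone core

The source may report more compounds than this note shows. Statements on the series, on what has been measured and on what is new or still open speak of the compounds shown alone.

Measured compounds:
compound 1, `Cc1cc(O)c(C(=O)/C=C/c2ccc(Cl)cc2)c(-c2ccccc2)c1C(=O)/C=C/c1ccc(Cl)cc1`, 30000 nM
compound 2, `Cc1cc(O)c(C(=O)/C=C/c2ccccc2)c(-c2ccc(Cl)cc2)c1C(=O)/C=C/c1ccccc1`, "not active" (no number reported)

Among the measured compounds shown here, compound 1 is the only compound here with a number. In a functional assay on HeLa cells (Homo sapiens) for cytotoxicity, read by MTT assay, with a stated time of 24 h (on this read-out lower numbers stand for stronger inhibition and higher numbers for weaker inhibition), compound 1 gives 30000 nM, a weak effect, since a large concentration is needed to reach the read-out. For the measured compounds named here, compound 2 carries a different arrangement of the same building blocks, and in this assay compound 2 is reported as "not active" (no number reported), without a number, so no step can be sized between the two.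

Compound 3, `Cc1cc(O)c(C(=O)/C=C/c2ccc(Cl)cc2)c(-c2ccc(Br)cc2)c1C(=O)/C=C/c1ccc(Cl)cc1`, keeps everything in compound 1 except one change: bromo in place of hydrogen on an aromatic carbon. Going by the values given here, no pair of measured compounds shows what such a single added halogen does on this core, so there is no step to lean on. With only the weak value of compound 1 as a base, the expectation is a step of no change at the digits printed from compound 1 to compound 3 (within the scatter) of no size beyond the usual scatter, in either direction. Compound 3 is therefore estimated at 30000 nM, with a plausible range from 10000 nM to 100000 nM.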

Compound 3, half-maximal inhibitory concentration: 32000 nM
Compound 3: the middle estimate sits 1.1-fold (0.03 log units) below what was measured; the range from low to high includes it.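

In this assay, bromo in place of hydrogen on an aromatic carbon, the swap of phenyl to 4-bromophenyl, gives a 1.1-fold higher number from compound 1 to compound 3 (0.03 log units; within the scatter) and so compound 1 and compound 3 cannot be told apart on this read-out. Among the compounds shown here, this is the first measured single-place comparison on the shared core, and it shows that this position can carry one added bromine while the reading stays in the same weak range, which the single number of compound 1 could not show alone. No outside measurement bears on this result, so it stands as a plain observation without an explanation.

Bromo is the only replacement shown at this position, so it remains open whether a different group there, such as an amine, a carboxylic acid or a longer alkyl chain, would give a clearly lower or higher number. Compound 2 has a chlorine on this same ring but no number, and the compounds shown do not reveal how much the chlorines on the two outer rings of compound 1 contribute to its weak effect.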